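A few compounds are considered here, and "the series" means these few. Any claim that something is new, unique, unknown or untested is made for them only; others in the source may bear on it.

Working notes on the aminopyrazole set. In an assay on HEK293 cells for inhibition of Leucine-rich repeat serine/threonine-protein kinase 2 variant G2019S (Homo sapiens), with a stated time of 48 h (on this read-out higher numbers stand for weaker inhibition and lower numbers for stronger inhibition), compound 1 `Cc1c(Nc2nc(N)c3c(C#N)c(N4CCC[C@H]4C)n(C)c3n2)cnn1[C@H]1CCOC1` gives 51 nM and stands at the lowest of the two single numbers recorded; its nearest neighbour, compound 3 `Cc1nn(CC(C)(C)O)cc1Nc1nc(N)c2c(C#N)c(N3CCC[C@H]3C)n(C)c2n1`, gives 180 nM, a gap beyond the scatter. Compound 2 `Cc1nn(C2CCOC2)cc1Nc1nc(N)c2c(C#N)c(N3CCC[C@H]3C)n(C)c2n1` has several entries in this assay, 65 nM; 180 nM (2 entries), and the several entries of compound 2 in this assay, 65 nM; 180 nM (2 entries) shows how widely repeat runs of one compound can spread here, so compound 2 is placed against neither of the others.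

Compound 4 `Cc1c(Nc2nc(N)c3c(C#N)c(N4CCC[C@H]4C)n(C)c3n2)cnn1CC(C)(C)O` is not yet measured. It differs from compound 1 by 2-hydroxy-2-methylpropyl in place of oxolan-3-yl on an aromatic nitrogen. Going by the values given here, no measured pair in the set shows this step directly. What the numbers show is that compound 3, which carries the 2-hydroxy-2-methylpropyl group, sits at the weaker end, while compound 2 spreads over both ends. On that basis a modest loss is expected, the step from compound 1 to compound 4 estimated at a 2.0-fold higher number from compound 1 to compound 4 (0.29 log units; within the scatter). For compound 4 in this assay the expected value is 100 nM, within a range of 40 nM to 250 nM.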

Compound 4, half-maximal inhibitory concentration: 120 nM
Estimate against measurement, compound 4: 1.2-fold (0.08 log units) below, and the stated range covers the measured number.
By their numbers in this assay, from the lowest: compound 1; then compounds 4 and 3 (each within the scatter of the next).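

In this assay, the change on the aromatic nitrogen now has a direct reading, with 2-hydroxy-2-methylpropyl in place of oxolan-3-yl giving a 2.4-fold higher number from compound 1 to compound 4 (0.37 log units; beyond the scatter). This change removes the ring and the defined stereocentre and adds a hydrogen-bond donor, and the resulting loss is only modest, so an open chain is tolerated at this position on the shared core. This is a single pair and calls for caution, because repeat runs of one compound can spread widely here: the several entries of compound 2 in this assay, 65 nM; 180 nM (2 entries).

One pair cannot separate the contributions of the lost ring, the lost stereocentre and the added hydroxyl. From the compounds shown here alone, how an amine, a carboxylic acid or a longer chain ending in a hydroxyl would read on this nitrogen remains open.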